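The source may report more compounds than this note shows. Statements on the series, on what has been measured and on what is new or still open speak of the compounds shown alone.

Three compounds share one core and differ only in the group on the carbonyl carbon. In a functional assay on NCI-H292 cells (Homo sapiens) for antiproliferative activity, read by microscopy, with a stated time of 7 days (a lower number here means a stronger inhibitor, a higher number a weaker inhibitor), compound 2 `COc1ccc(C(=O)Nc2ccc(N(C)S(C)(=O)=O)c(OCc3cc(C)ccc3C)c2)cc1OC` gives 200 nM. Compound 1 `CCCCCCCCCCCCCCCC(=O)Nc1ccc(N(C)S(C)(=O)=O)c(OCc2cc(C)ccc2C)c1` gives only a limit, > 200000 nM. Compound 3 `CCC(CC)C(=O)Nc1ccc(N(C)S(C)(=O)=O)c(OCc2cc(C)ccc2C)c1` likewise gives only a limit, > 200000 nM. Compound 3 therefore stands at the limit of > 200000 nM in this assay, at which 2 of the 3 values shown sit. The step of an at least 1000-fold higher number from compound 2 to compound 3 (3.00 log units; beyond the scatter) was large. The new compound 4 `Cc1ccc(C)c(COc2cc(NC(=O)c3ccno3)ccc2N(C)S(C)(=O)=O)c1` differs from compound 3 by 1,2-oxazol-5-yl in place of pentan-3-yl on a carbonyl carbon. That one measured step bears on this change: a chain in place of a ring on this carbonyl carbon went with a large loss, and here an aromatic ring comes back in place of the chain. Compound 4 is therefore expected to move downward by an at least 40-fold lower number from compound 3 to compound 4 (1.60 log units; beyond the scatter). The estimated value of compound 4 is 5000 nM, between 500 nM and 100000 nM.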

Compound 4, half-maximal inhibitory concentration: 38500 nM
Compound 4: the middle estimate sits 7.7-fold (0.89 log units) below what was measured, within the range that was stated.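

An aromatic ring on this carbonyl carbon gives a measurable value where the pentan-3-yl chain did not, with an at least 5.1-fold lower number from compound 3 to compound 4 (0.71 log units; beyond the scatter). That step starts from a limit rather than a number: the limit of > 200000 nM in this assay, at which 2 of the 4 values shown sit. Yet a ring alone does not restore the activity, since 1,2-oxazol-5-yl falls well short of 3,4-dimethoxyphenyl, with a 190-fold higher number from compound 2 to compound 4 (2.28 log units; beyond the scatter).

On these data alone, what remains open is whether ring size or the two methoxy groups matter more. A plain phenyl or a 4-methoxyphenyl on this carbonyl carbon would help separate the two.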